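This account rests on a few compounds, and the source may have more. Where it says the series, first, only, none or still open, it means among the compounds named here.

In a toxicity assay on HeLa cells (Homo sapiens) for cytotoxicity (a higher number here means that more compound is tolerated, a lower number that less compound is tolerated), two compounds of this series have been examined so far. Compound 1, `COc1nc(-c2cccc(Cl)c2)ccc1[C@@H](c1ccccc1)[C@@](O)(CCN(C)C)c1cccc2ccccc12`, has no result recorded there: "nd" (no result reported). Compound 2, `COc1nc(-c2ccsc2)ccc1[C@@H](c1ccccc1)[C@@](O)(CCN(C)C)c1cccc2ccccc12`, reached only the limit of this assay, at > 64 ug/mL, so a single number is not known for it. Its entry corresponds to the limit of > 64 ug/mL in this assay, at which 1 of the 2 values shown sits. Compound 3, `COc1nc(C2CCCCC2)ccc1[C@@H](c1ccccc1)[C@@](O)(CCN(C)C)c1cccc2ccccc12`, is the next one to be tested in this assay, and it differs from compound 2 in one place: cyclohexyl in place of thiophen-3-yl on an aromatic carbon. Going by the values given here, no pair of measured compounds that differ in a single place is available, so the size of a change of this kind cannot be read off from what has been measured. With compound 2 already sitting at the limit, the step is expected to be small, within the scatter or again ending at the limit, as a step that the limit leaves unreadable from compound 2 to compound 3. Compound 3 is estimated to show 80 ug/mL in this assay, with a range from 30 ug/mL to 200 ug/mL.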

Compound 3, half-maximal cytotoxic concentration: 57.7 ug/mL
Compound 3: middle estimate off by 1.4-fold (0.14 log units), on the high side, and the stated range covers the measured number.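

Compound 3 gives this series its first single number in this assay, at 57.7 ug/mL, so a ring that is neither aromatic nor contains a hetero atom can sit on this aromatic carbon next to the ring nitrogen and still yield a measurable result. Putting cyclohexyl in place of thiophen-3-yl gives an at least 1.1-fold lower number from compound 2 to compound 3 (0.04 log units; that floor lies within the scatter), so the part of this step that can be read does not go beyond the scatter, even though an aromatic ring with sulfur has given way to a non-aromatic ring of carbon only. The true size of the step cannot be read, because compound 2 stands at a limit of the assay: the limit of > 64 ug/mL in this assay, at which 1 of the 3 values shown sits.

The compounds shown leave open whether a different kind of group at this place, such as an amine, a carboxylic acid or a longer chain, would move the tolerated concentration further than the scatter. Also open, going by these compounds, is whether cyclohexyl would behave in the same way elsewhere on the shared core, as one exchange at one place is all that can be followed here.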